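From 2-chlorophenyl to 3-aminophenyl in compound 4

The compounds below may be only part of what the source reports. "The series", "measured", "known", "first", "only" and "open" are said of these compounds alone.

Measured so far in a functional assay on MCF7 cells (Homo sapiens) for cytotoxicity, read by MTT assay, with a stated time of 96 h; a higher number here means a weaker inhibitor, a lower number a stronger inhibitor:
compound 1 `COc1cc(C(=O)c2cn(-c3ccc(C)cc3)cc2-c2cccc(N)c2)cc(OC)c1OC` gives 53 nM
compound 2 `COc1cc(C(=O)c2cn(-c3ccc(N)cc3)cc2-c2ccccc2F)cc(OC)c1OC` gives 28 nM
compound 3 `COc1cc(C(=O)c2cn(-c3ccc(N)cc3)cc2-c2ccccc2Cl)cc(OC)c1OC` gives 83 nM

The numbers of compound 3 and compound 1 lie within the scatter of each other, so compound 3 stands with compound 1 and clear of compound 2 only. Within the data shown here, the one measured step is a 3.0-fold higher number from compound 2 to compound 3 (0.47 log units; beyond the scatter), with chloro in place of fluoro on an aromatic carbon.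

Compound 4 `COc1cc(C(=O)c2cn(-c3ccc(N)cc3)cc2-c2cccc(N)c2)cc(OC)c1OC` has 3-aminophenyl in place of 2-chlorophenyl on an aromatic carbon. The measured step bears on this place but brings in no 3-aminophenyl. Compound 1 does carry 3-aminophenyl, without the 4-aminophenyl group, and its 53 nM is the closest guide. In this assay, among the measured compounds shown here, no step clearly beyond the scatter is therefore expected, with a lean toward a lower number. The expected step is a 1.8-fold lower number from compound 3 to compound 4 (0.27 log units; within the scatter) at its middle. The estimate for compound 4 is 45 nM (expected range 14 nM to 140 nM).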

Compound 4, half-maximal inhibitory concentration: 78 nM
Beside the measured number, compound 4's estimate is 1.7-fold (0.24 log units) below it; the measured number falls inside the stated range.
By their numbers in this assay, from the lowest: compounds 2, 1, 4 and 3 (each within the scatter of the next, the first and the last beyond it).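

In this assay, the change at this position gives a 1.1-fold lower number from compound 3 to compound 4 (0.03 log units; within the scatter), so 3-aminophenyl and 2-chlorophenyl cannot be told apart here, whereas 2-fluorophenyl at the same place stands clear of 3-aminophenyl, with a 2.8-fold higher number from compound 2 to compound 4 (0.44 log units; beyond the scatter). With 3-aminophenyl held in place, amino in place of methyl on the other aromatic ring gives a 1.5-fold higher number from compound 1 to compound 4 (0.17 log units; within the scatter), so this exchange also stays within the scatter. No available evidence accounts for the separation of 2-fluorophenyl from the other two groups at this position.

The compounds shown leave open whether 2-aminophenyl would match 3-aminophenyl, which would show whether the place of the amine on this ring matters. They also leave open whether 3-fluorophenyl or 3-chlorophenyl would keep the number seen with its 2-substituted counterpart.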